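The compounds below may be only part of what the source reports. "The series", "measured", "known", "first", "only" and "open" are said of these compounds alone.

In a functional assay on BJAB cells (Homo sapiens) for antiproliferative activity, with a stated time of 4 days (on this read-out lower numbers stand for an effect already at smaller amounts and higher numbers for an effect only at larger amounts of compound), compound 2 `Cc1nn(-c2nc(-c3ccc(Cl)c(Cl)c3)c(SC(C)C)s2)c(C(=O)O)c1-c1cccc(F)c1` gives 900 nM. That is the lowest of the two numbers recorded in this assay; the nearest is compound 3 `Cc1nn(-c2nc(-c3ccc(Cl)c(Cl)c3)c(SC(C)C)s2)c(C(=O)O)c1-c1cncc(C#N)c1`, which gives 20000 nM. Compound 1 `Cc1c(-c2cc(Cl)cc(Cl)c2)c(C(=O)O)nn1-c1nc(-c2cccnc2)c(SC(C)C)s1` was reported as "not active" (no number reported) in this assay, with no number attached.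

Compound 4 `COc1ccccc1-c1c(C)nn(-c2nc(-c3ccc(Cl)c(Cl)c3)c(SC(C)C)s2)c1C(=O)O` has not yet been measured in this assay. It differs from compound 2 in one place: 2-methoxyphenyl in place of 3-fluorophenyl on an aromatic carbon.

For the measured compounds named here, only one measured step bears on this exchange, namely a 22-fold higher number from compound 2 to compound 3 (1.35 log units; beyond the scatter), in which the 3-fluorophenyl gave way to a ring carrying a ring nitrogen and a nitrile. The change toward compound 4 is of a different kind: the entering 2-methoxyphenyl keeps a six-membered aromatic ring of carbon only and brings a single hydrogen-bond acceptor. Going by the values given here, nothing among the measured compounds shows what a methoxy group at this place does, so the step to compound 3 is the only guide, and it is expected to overstate the case. A step toward higher numbers is therefore expected for compound 4, but a small one that may well lie within the scatter: a 1.7-fold higher number from compound 2 to compound 4 (0.22 log units; within the scatter) is the expected outcome. Compound 4 is thus estimated at 1500 nM in this assay, within a range from 500 nM to 5000 nM.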

Compound 4, half-maximal effective concentration: 14700 nM
For compound 4 the middle estimate is 9.8-fold (0.99 log units) below the measured one, and the stated range ends below it.
By their numbers in this assay, from the lowest: compound 2; then compounds 4 and 3 (each within the scatter of the next).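

In this assay, 2-methoxyphenyl in place of 3-fluorophenyl gives a 16-fold higher number from compound 2 to compound 4 (1.21 log units; beyond the scatter) and is thus a large step, although the entering group keeps a six-membered aromatic ring of carbon only. The earlier 22-fold higher number from compound 2 to compound 3 (1.35 log units; beyond the scatter) could have been read as tied to the ring nitrogen or the nitrile of 5-cyanopyridin-3-yl, but the present step shows that a group with neither can also carry a large step at this aromatic carbon. The two entering groups differ widely yet remain within the scatter of each other, with a 1.4-fold lower number from compound 3 to compound 4 (0.13 log units; within the scatter), so among these three compounds only compound 2 stands apart, and no measurement available here accounts for this.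

From the compounds shown here alone, it remains open whether the methoxy group itself or its place on the phenyl ring is behind the step, and whether a plain phenyl would stay close to compound 2 or fall with the other two. Also open, going by these compounds, is how an amine, a hydroxy group or a chlorine on that phenyl ring would behave at this aromatic carbon.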